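The compounds below may be only part of what the source reports. "The series", "measured", "known", "first", "only" and "open" are said of these compounds alone.

Measured so far in an ADME assay on MEpiC cells (Homo sapiens) for antiproliferative activity, read by MTT assay, with a stated time of 48 h; a higher number here means a weaker inhibitor, a lower number a stronger inhibitor:
compound 1 `O=C1C=CC2(C=C1)OC(=O)C(I)=C2c1ccccc1`: 6330 nM
compound 2 `O=C1C=CC2(C=C1)OC(=O)C(c1cc3ccccc3o1)=C2c1ccccc1`: 66600 nM

Among the compounds with values here, compound 2 stands highest of the two numbers in this assay; its nearest neighbour is compound 1, and the only measured step, an 11-fold higher number from compound 1 to compound 2 (1.02 log units; beyond the scatter), is large and beyond the scatter. Compound 3 `COc1ccc(C2=C(c3ccccc3)C3(C=CC(=O)C=C3)OC2=O)cc1` differs from compound 2 by 4-methoxyphenyl in place of 1-benzofuran-2-yl on a double-bonded ring carbon. Within the data shown here, no measured step exchanges one aryl group for another at this carbon; the step from compound 1 to compound 2 bears on it only indirectly, showing that an aryl group in place of iodo at that place carries a much higher number than iodo. Compound 3 keeps an aryl group there, so its number is expected to lie nearer compound 2 than compound 1, and the expected step of a 2.2-fold lower number from compound 2 to compound 3 (0.35 log units; beyond the scatter) is a modest lowering, not clearly beyond the scatter. For compound 3 the estimate in this assay is 30000 nM, with a range from 8000 nM to 100000 nM.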

Compound 3, half-maximal inhibitory concentration: 11700 nM
Compound 3: middle estimate off by 2.6-fold (0.41 log units), on the high side; measured number inside the range.
By their numbers in this assay, from the lowest: compounds 1 and 3 (each within the scatter of the next); then compound 2.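

In this assay the identity of the aryl group on this double-bonded ring carbon matters: with a 5.7-fold lower number from compound 2 to compound 3 (0.76 log units; beyond the scatter) the exchange of 1-benzofuran-2-yl for 4-methoxyphenyl gives a change beyond the scatter, which the earlier iodo comparison could not show. With a 1.8-fold higher number from compound 1 to compound 3 (0.27 log units; within the scatter) the 4-methoxyphenyl compound cannot be told apart from the iodo compound, so the large rise seen with 1-benzofuran-2-yl does not extend to both aryl groups shown at this place. No evidence on the cause of these differences is available.

The compounds shown leave open whether the methoxy group of 4-methoxyphenyl has any part in this result. They also leave open how a carboxylic acid or an amine at this carbon would read against compound 1 and compound 3.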